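This account rests on a few compounds, and the source may have more. Where it says the series, first, only, none or still open, it means among the compounds named here.

Measured compounds:
compound 1, `CS(=O)(=O)Nc1ccc2c(c1)S(=O)(=O)N=C(C1=C(O)C3CCCC3N(Cc3ccc(F)cn3)C1=O)N2`; in an ADME assay on Huh-7 cells (Homo sapiens) for cytotoxicity, with a stated time of 72 h (a higher number here means that more compound is tolerated, a lower number that less compound is tolerated), compound 1 gives > 33000 nM, which is a limit of the assay and not a number.
compound 2, `CC(C)CCN1C(=O)C(C2=NS(=O)(=O)c3cc(NS(C)(=O)=O)ccc3N2)=C(O)C2CCCC21`; in this assay compound 2 gives > 1000 nM, again a limit.
compound 3, `CS(=O)(=O)Nc1ccc2c(c1)S(=O)(=O)N=C(C1=C(O)C3CCCC3N(Cc3ccc(Cl)cc3)C1=O)N2`; in this assay compound 3 gives > 10000 nM, also a limit.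

Compound 3 therefore stands at a limit, and the two other values shown are limits as well, so no ordering among the three can be read. The steps among them confirm this: a step that the two limits leave unreadable from compound 1 to compound 3, a step that the two limits leave unreadable from compound 2 to compound 3 and a step that the two limits leave unreadable from compound 1 to compound 2, each left unreadable by the limits at either end (the limit of > 1000 nM in this assay, at which 1 of the 3 values shown sits, (the limit of > 10000 nM in this assay, at which 1 of the 3 values shown sits), (the limit of > 33000 nM in this assay, at which 1 of the 3 values shown sits)).

Compound 4, `CS(=O)(=O)Nc1ccc2c(c1)S(=O)(=O)N=C(C1=C(O)C3CCCC3N(Cc3ccccc3)C1=O)N2`, differs from compound 3 by hydrogen in place of chloro on an aromatic carbon. Among the compounds with values here, none of the measured steps gives a readable size for a change on the benzyl group in this assay, and all three compounds sit at limits, so no step beyond the scatter is expected from compound 3 to compound 4. Compound 4 is therefore estimated to sit at a limit as well, a step that the limit leaves unreadable from compound 3 to compound 4, with an expected value of 20000 nM between 5000 nM and 80000 nM.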

Compound 4, half-maximal cytotoxic concentration: > 33000 nM
Compound 4: no number, only a limit (the forecaster's own chance of this, stated with the estimate: 85%); at least 1.6-fold (0.21 log units) between middle value and limit.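

In this assay compound 4 gives > 33000 nM, which is a limit of the assay and not a number. None of the steps to compound 4 from compound 1, compound 2 or compound 3 can be read. The compounds shown leave open where any of the four actually becomes cytotoxic and whether the group on the amide-type nitrogen changes this.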